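Piperidine for pyrrolidine at the thiocarbonyl carbon in a nitroimidazole series

The source may hold more compounds than are shown below. What is called first, only, known or untested is meant among the compounds shown, and "the series" means these compounds.

Measured so far:
compound 1, `Cc1ncc([N+](=O)[O-])n1CCSC(=S)N1CCC(OC(=O)CSC(=S)N2CCCC2)CC1` — > 1000 ug/mL
compound 2, `Cc1ncc([N+](=O)[O-])n1CCSC(=S)N1CCCC(C)C1` — 170 ug/mL

In an ADME assay on HeLa cells (Homo sapiens) for cytotoxicity (on this read-out lower numbers stand for stronger inhibition and higher numbers for weaker inhibition), compound 1 gives > 1000 ug/mL, which is a limit of the assay and not a number, so compound 1 stands only at the limit of > 1000 ug/mL in this assay, at which 1 of the 2 values shown sits. Compound 2 gives a number, 170 ug/mL. Among the measured compounds shown here, no step between measured compounds is available here. Compound 3, `Cc1ncc([N+](=O)[O-])n1CCSC(=S)N1CCC(OC(=O)CSC(=S)N2CCCCC2)CC1`, differs from compound 1 by piperidin-1-yl in place of pyrrolidin-1-yl on a thiocarbonyl carbon. The expected step of a number no higher from compound 1 to compound 3 (the limit leaves the size open) is none beyond the usual scatter. Compound 3 is therefore estimated at 1000 ug/mL, within 500 ug/mL to 2000 ug/mL, and another limit is the more likely outcome.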

Compound 3, half-maximal inhibitory concentration: 980 ug/mL
For compound 3 the middle estimate is 1.0-fold (0.01 log units) above the measured one, within the range that was stated.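

In this assay, among the compounds shown here, piperidin-1-yl in place of pyrrolidin-1-yl on a thiocarbonyl carbon gives an at least 1.0-fold lower number from compound 1 to compound 3 (0.00 log units; that floor lies within the scatter) as the only step read at this position. The larger ring leaves compound 3 with 980 ug/mL as a true number. The size of the step stays open, because the value of compound 1 is a limit of the assay and not a number: the limit of > 1000 ug/mL in this assay, at which 1 of the 3 values shown sits.

The compounds shown leave open how morpholin-4-yl or a diethylamino group would read on the same thiocarbonyl carbon.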